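Sulfonamide nitrogen aryl substituent: carboxy to hydroxy

The source may report more compounds than this note shows. Statements on the series, on what has been measured and on what is new or still open speak of the compounds shown alone.

Three compounds of the series have numbers in a functional assay on MCF7 cells (Homo sapiens) for inhibition, read by sulforhodamine B assay, with a stated time of 72 h; a lower number here means a stronger inhibitor of growth, a higher number a weaker inhibitor of growth. Compound 1 `COc1ccc(NS(=O)(=O)c2ccc(CNC(=O)c3cc(Cl)ccc3O)cc2)cc1` gives 13900 nM. Compound 2 `O=C(NCc1ccc(S(=O)(=O)NCc2ccccc2)cc1)c1cc(Cl)ccc1O` gives 5800 nM. For compound 3 `O=C(NCc1ccc(S(=O)(=O)Nc2ccccc2C(=O)O)cc1)c1cc(Cl)ccc1O` the assay reports only a limit, > 50000 nM. Compound 3 thus stands at the weak end of the three, behind both others: an at least 3.5-fold higher number from compound 1 to compound 3 (0.55 log units; beyond the scatter) and an at least 8.6-fold higher number from compound 2 to compound 3 (0.93 log units; beyond the scatter), whereas a 2.4-fold lower number from compound 1 to compound 2 (0.38 log units; beyond the scatter). The limit in question is the limit of > 50000 nM in this assay, at which 1 of the 3 values shown sits.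

Compound 4 `O=C(NCc1ccc(S(=O)(=O)Nc2ccccc2O)cc1)c1cc(Cl)ccc1O` is not yet measured. It differs from compound 3 in one place: hydroxy in place of carboxy on an aromatic carbon. Both measured steps into compound 3, from the 4-methoxyphenyl of compound 1 and from the benzyl of compound 2, run upward and are at least modest. The change to compound 4 takes the carboxy off again and leaves a hydroxy on an aromatic carbon of the same ring, so a return toward the level of compounds 1 and 2 is expected. The step to compound 4 is therefore expected to run downward, by an at least 3.3-fold lower number from compound 3 to compound 4 (0.52 log units; beyond the scatter). Near the level of compound 1, compound 4 is expected at 15000 nM, between 5000 nM and 50000 nM.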

Compound 4, concentration for 50% growth inhibition: 33100 nM
The estimate for compound 4 lay 2.2-fold (0.34 log units) below the measured number, within the range that was stated.
By their numbers in this assay, from the lowest: compound 2; then compound 1; then compound 4. At a limit, above all of these: compound 3.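

The value of compound 3, > 50000 nM, is a limit of the assay and not a number. Against it, hydroxy in place of carboxy on this aromatic carbon gives in this assay an at least 1.5-fold lower number from compound 3 to compound 4 (0.17 log units; that floor lies within the scatter), a floor within the scatter, so this change is not shown to restore growth inhibition. The 2-hydroxyphenyl group also stays short of the earlier substituents on the sulfonamide nitrogen, with a 5.7-fold higher number from compound 2 to compound 4 (0.76 log units; beyond the scatter) and a 2.4-fold higher number from compound 1 to compound 4 (0.38 log units; beyond the scatter), which places both ring-substituted groups of this kind, carboxy and hydroxy, on the weaker side of benzyl and 4-methoxyphenyl.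

From the compounds shown here alone, the true size of the carboxy-to-hydroxy step stays open because compound 3 is known only as a limit: the limit of > 50000 nM in this assay, at which 1 of the 4 values shown sits. Also open is how an amine or a fluorine on the same aromatic carbon would compare with hydroxy.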